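A Chain Exchange on Compound 1

A few compounds are considered here, and "the series" means these few. Any claim that something is new, unique, unknown or untested is made for them only; others in the source may bear on it.

Measured so far in a functional assay on J774.1 cells (Mus musculus) for inhibition, read by Griess assay; on this read-out lower numbers stand for stronger inhibition and higher numbers for weaker inhibition:
- compound 1 `CCCCCCCCS(=O)(=O)NCCCN(CCCNCCCCNCCCN)CCCNS(=O)(=O)CCCCCCCC` gives 1820 nM
- compound 2 `CCCCCCCCCCS(=O)(=O)NCCCN(CCCNCCCCNCCCN)CCCNS(=O)(=O)CCCCCCCCCC` gives 1100 nM

Compound 1 at 1820 nM and compound 2 at 1100 nM lie within the usual scatter of repeated measurements. Among the measured compounds shown here, these two numbers therefore cannot be ranked, and compound 1 stands level with the only other measured compound.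

Compound 3 `CCCCCCCCS(=O)(=O)NCCCN(CCCNCCCNCCCCNCCCN)CCCNS(=O)(=O)CCCCCCCC` keeps the core of compound 1 but carries (4-((3-aminopropyl)amino)butyl)amino in place of ((3-aminopropyl)amino)methyl on a saturated chain carbon, three bonds along the chain from an amine nitrogen.

For the measured compounds named here, no measured step yet shows what this kind of exchange does. With no evidence for a direction, the expected 1.2-fold lower number from compound 1 to compound 3 (0.08 log units; within the scatter) in this assay stays within the scatter. For compound 3 the estimated value is 1500 nM, with an expected range from 600 nM to 3800 nM.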

Compound 3, half-maximal inhibitory concentration: 320 nM
Estimate against measurement, compound 3: 4.7-fold (0.67 log units) above; measured number outside the range, below it.
By their numbers in this assay, from the lowest: compound 3; then compounds 2 and 1 (each within the scatter of the next).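

In this assay, among the compounds shown here, putting (4-((3-aminopropyl)amino)butyl)amino in place of ((3-aminopropyl)amino)methyl on a saturated chain carbon, three bonds along the chain from an amine nitrogen, gives a 5.7-fold lower number from compound 1 to compound 3 (0.75 log units; beyond the scatter), the first step here that lies beyond the scatter. The number therefore responds to a change at this position, and in this one step the larger amine chain goes with stronger inhibition. No measurement here explains the drop, and this single step cannot separate the added chain length from the added amine nitrogen.

Open, from the compounds shown here alone, is whether a still longer amine chain would go further, or whether an ether oxygen in place of the added amine nitrogen would do the same. Also open, going by these compounds, is whether this exchange has the same effect on compound 2, with its longer sulfonyl chains.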